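A few compounds are considered here, and "the series" means these few. Any claim that something is new, unique, unknown or untested is made for them only; others in the source may bear on it.

Measured in a functional assay on KYSE-450 cells (Homo sapiens) for inhibition, read by MTT assay, with a stated time of 48 h; a higher number here means a weaker inhibitor, a lower number a stronger inhibitor:
- compound 1 `COc1ccc(CN(C(=O)CN=[N+]=[N-])c2cc(OC)c(OC)c(OC)c2)cc1O`: 160 nM
- compound 2 `COc1ccc(CN(C(=O)CCCCCl)c2cc(OC)c(OC)c(OC)c2)cc1O`: 770 nM

Compound 2 gives 770 nM, the higher of the two numbers, so it is the weaker inhibitor here. Compound 3 `COc1ccc(CN(C(=O)C[Se]C#N)c2cc(OC)c(OC)c(OC)c2)cc1O` is still unmeasured. It differs from compound 2 on a saturated chain carbon bound to a carbonyl carbon: a group of 3 heavy atoms (1 carbon, 1 nitrogen, 1 selenium; no ring) in place of a group of 4 heavy atoms (3 carbon, 1 chlorine; no ring), on a saturated chain carbon bound to a carbonyl carbon. Going by the values given here, one measured step bears on this place, a 4.8-fold higher number from compound 1 to compound 2 (0.68 log units; beyond the scatter), a modest step. With so little evidence, a step of similar size towards a stronger inhibitor is expected in this assay, though this is uncertain. The expected change is a 3.9-fold lower number from compound 2 to compound 3 (0.59 log units; beyond the scatter). For compound 3 the estimate is 200 nM, with an expected range of 50 nM to 800 nM.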

Compound 3, half-maximal inhibitory concentration: 280 nM
The estimate for compound 3 lay 1.4-fold (0.15 log units) below the measured number; the range from low to high includes it.
By their numbers in this assay, from the lowest: compounds 1 and 3 (each within the scatter of the next); then compound 2.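

At this place, on a saturated chain carbon bound to a carbonyl carbon, a second group now outperforms 3-chloropropyl: a 2.8-fold lower number from compound 2 to compound 3 (0.44 log units; beyond the scatter) makes compound 3 the stronger inhibitor. Set against the azido group, the new group gives a 1.8-fold higher number from compound 1 to compound 3 (0.24 log units; within the scatter) and so cannot be told apart from it, which means two groups of quite different atoms give matching results here. Nothing measured explains why either group does better than 3-chloropropyl. Still open, as far as these compounds go, is how an amine, a carboxylic acid or a plain nitrile would fare at this place.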